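A few compounds are considered here, and "the series" means these few. Any claim that something is new, unique, unknown or untested is made for them only; others in the source may bear on it.

Compound 2 `O=C(N/N=C/c1ccccc1O)c1nc2ccccc2nc1-c1ccccc1` stands at the edge of what an ADME assay on J774 cells (Mus musculus) for cytotoxicity, read by MTT assay, with a stated time of 48 h (a lower number here means a stronger inhibitor, a higher number a weaker inhibitor), can report: in this assay compound 2 gives > 400000 nM, which is a limit rather than a number. Compound 1 `Cc1nc2ccccc2nc1C(=O)N/N=C/c1ccccc1O` gives in this assay > 400000 nM, likewise a limit. The step that the two limits leave unreadable from compound 1 to compound 2, a phenyl in place of methyl on an aromatic carbon, stays unreadable because of the limit of > 400000 nM in this assay, at which 2 of the 2 values shown sit. Compound 3 `O=C(N/N=N/c1cccs1)c1nc2ccccc2nc1-c1ccccc1` differs from compound 2 by a group of 7 heavy atoms (4 carbon, 2 nitrogen, 1 sulfur; one five-membered aromatic ring with 1 hetero atom) in place of a group of 9 heavy atoms (7 carbon, 1 nitrogen, 1 oxygen; one six-membered aromatic ring of carbon only), on an amide-type nitrogen. Among the measured compounds shown here, no measured step touches this change, so the numbers give no direction for it. Compound 3 is expected to give 400000 nM in this assay, within 100000 nM to 1000000 nM. The expected step is a number no higher from compound 2 to compound 3 (the limit leaves the size open).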

Compound 3, half-maximal inhibitory concentration: > 400000 nM
Compound 3: a limit, no number; the forecaster's own chance of this, stated with the estimate: 70%; the middle value lies on the limit itself.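

No step can be read between compound 2 and compound 3, because the result rests on a single limit: the limit of > 400000 nM in this assay, at which 3 of the 3 values shown sit.

The compounds shown leave open where compound 1, compound 2 and compound 3 would each give an actual number in this assay, and whether either change shifts it.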